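The compounds below may be only part of what the source reports. "The series", "measured", "known", "first", "only" and "open" are said of these compounds alone.

Working notes on the series. All three measured members share one core and differ only in the group on the nitrogen on an aromatic ring. Compound 1 `CCCNc1nc(-c2ccccc2)nc2c1nnn2Cc1ccccc1` gives 37 nM in an assay on Cerebral cortex for displacement of a labelled ligand from adenosine receptor A1 (Bos taurus); a lower number here means a stronger inhibitor, a higher number a weaker inhibitor. Compound 2 `CCCCNc1nc(-c2ccccc2)nc2c1nnn2Cc1ccccc1` gives 11 nM in this assay. Compound 3 `c1ccc(Cn2nnc3c(NC4CC4)nc(-c4ccccc4)nc32)cc1` gives 11.3 nM in this assay. On these numbers compound 3 stands second of three: the closest number is that of compound 2, with a 1.0-fold higher number from compound 2 to compound 3 (0.01 log units; within the scatter), and the furthest is that of compound 1, with a 3.3-fold lower number from compound 1 to compound 3 (0.52 log units; beyond the scatter). Compound 4 `c1ccc(Cn2nnc3c(NC4CCC4)nc(-c4ccccc4)nc32)cc1` is the next member; the change is cyclobutyl in place of cyclopropyl on a nitrogen on an aromatic ring. Among the measured compounds shown here, the steps that bear on it are the two at the same nitrogen: a 3.4-fold lower number from compound 1 to compound 2 (0.53 log units; beyond the scatter), where methyl replaced hydrogen on the chain, and a 1.0-fold higher number from compound 2 to compound 3 (0.01 log units; within the scatter), where cyclopropyl replaced butyl. One more carbon on the open chain gave a modest gain, and the three-membered ring matched the four-carbon chain, so for a four-membered ring a step within the scatter, or at most a small move to a lower number, is expected. The expected step for compound 4 is a 1.4-fold lower number from compound 3 to compound 4 (0.15 log units; within the scatter). Compound 4 is thus estimated at 8 nM in this assay, with a range from 3 nM to 25 nM.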

Compound 4, inhibition constant: 5 nM
For compound 4 the middle estimate is 1.6-fold (0.20 log units) above the measured one, and the stated range covers the measured number.
By their numbers in this assay, from the lowest: compound 4; then compounds 2 and 3 (each within the scatter of the next); then compound 1.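

In this assay, going from the three-membered to the four-membered ring on this nitrogen gives a step beyond the scatter, a 2.3-fold lower number from compound 3 to compound 4 (0.35 log units; beyond the scatter), so the level shared by the cyclopropyl and butyl compounds is not the lowest number reachable at this position. Cyclobutyl also improves on both open chains, with a 2.2-fold lower number from compound 2 to compound 4 (0.34 log units; beyond the scatter) and a 7.4-fold lower number from compound 1 to compound 4 (0.87 log units; beyond the scatter), which places compound 4 lowest of the four, with every step to it beyond the scatter. No measurement is available that bears on the reason for these steps.

As far as these compounds go, whether the gain continues with larger rings, such as cyclopentyl or cyclohexyl, remains open. Also open, from the compounds shown here alone, is how cyclobutyl compares with a branched chain such as isopropyl, a longer chain such as pentyl, or a hydroxyl on the cyclobutyl ring.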